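The compounds below may be only part of what the source reports. "The series", "measured", "known", "first", "only" and "open" are said of these compounds alone.

Working notes on the series.

Three members have numbers in an assay on membranes from Chem-1 cells for displacement of a labelled ligand from prostaglandin E2 receptor EP3 subtype (Homo sapiens), read by scintillation counting, with a stated time of 2 h; a lower number here means a stronger inhibitor, a higher number a weaker inhibitor. Compound 1 `CC(C)C(CC1C(=O)NC(=O)N1C)c1ccc(-c2ccc3cccc(F)c3c2)[nH]c1=O` gives 17 nM. Compound 2 `CC(C)C(c1ccc(-c2ccc3cccc(F)c3c2)[nH]c1=O)C1NC(=O)NC1=O` gives 50 nM. Compound 3 `CC(C)C(CC1NC(=O)NC1=O)c1ccc(-c2ccc3cccc(F)c3c2)[nH]c1=O` gives 10 nM and so carries the lowest number of the three, though its gap to compound 1 lies within the scatter and only its gap to compound 2 lies beyond it.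

The step to compound 4 `CC(C)C(/C=C1/C(=O)NC(=O)N1C)c1ccc(-c2ccc3cccc(F)c3c2)[nH]c1=O` replaces (a group of 9 heavy atoms (5 carbon, 2 nitrogen, 2 oxygen; one five-membered non-aromatic ring with 2 hetero atoms) in place of a group of 8 heavy atoms (4 carbon, 2 nitrogen, 2 oxygen; one five-membered non-aromatic ring with 2 hetero atoms), on a saturated chain carbon bound to an aromatic carbon and a saturated chain carbon). The entering group carries 3 double bonds outside aromatic rings and only 1 hydrogen-bond donor, where the leaving group carries 2 of each.

For the measured compounds named here, two measured steps touch this change. The methyl on the amide-type nitrogen in the ring is the only difference in a 1.7-fold lower number from compound 1 to compound 3 (0.23 log units; within the scatter), a step within the scatter. The length of the link from the chain carbon to the five-membered ring matters more: a 5.0-fold lower number from compound 2 to compound 3 (0.70 log units; beyond the scatter) and a 2.9-fold higher number from compound 1 to compound 2 (0.47 log units; beyond the scatter) are both modest and beyond the scatter. Going by the values given here, no measured step shows what the extra double bond outside the ring does. With the one-carbon link kept and the methyl already seen to cost little in compound 1, a small step is expected in this assay, if any, with a lean towards a higher number.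

Compound 4 is therefore estimated at 25 nM, range 8 nM to 80 nM, an expected step of a 2.5-fold higher number from compound 3 to compound 4 (0.40 log units; beyond the scatter).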

Compound 4, inhibition constant in the prostaglandin E2 receptor EP3 subtype assay: 6 nM
The estimate for compound 4 lay 4.2-fold (0.62 log units) above the measured number; measured number below the stated range.
By their numbers in the prostaglandin E2 receptor EP3 subtype assay, from the lowest: compounds 4, 3 and 1 (each within the scatter of the next, the first and the last beyond it); then compound 2.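

In the prostaglandin E2 receptor EP3 subtype assay, the group with 3 double bonds outside aromatic rings and 1 hydrogen-bond donor takes the place of (2,5-dioxoimidazolidin-4-yl)methyl without a readable change, a 1.7-fold lower number from compound 3 to compound 4 (0.22 log units; within the scatter), so the position on the saturated chain carbon accepts both groups equally within the scatter. In the prostaglandin E2 receptor EP3 subtype assay, the extra double bond outside the ring can now be read on its own, as the only difference in a 2.8-fold lower number from compound 1 to compound 4 (0.45 log units; beyond the scatter), and the linked ring keeps its lead over the directly attached 2,5-dioxoimidazolidin-4-yl in an 8.3-fold lower number from compound 2 to compound 4 (0.92 log units; beyond the scatter). The same change that leaves the number in the binding read-out within the scatter also separates the two compounds in a physicochemical assay for solubility, in phosphate buffer, measured as kinetic solubility; on this read-out lower numbers stand for lower solubility and higher numbers for higher solubility: the measured solubility of compound 3, 12300 nM, and of compound 4, 34800 nM, a 2.8-fold higher number (0.45 log units; beyond the scatter) In the physicochemical assay compound 3 gives 12300 nM and compound 4 gives 34800 nM on the same read-out.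

The compounds shown leave open how that solubility step divides between the methyl on the ring nitrogen and the extra double bond outside the ring. Also open, as far as these compounds go, is whether the same saturated chain carbon would accept a carboxylic acid or an amine at the end of a longer chain in place of the five-membered ring.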